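This account rests on a few compounds, and the source may have more. Where it says the series, first, only, none or still open, it means among the compounds named here.

Measured compounds in a functional assay on A549 cells (Homo sapiens) for antiproliferative activity, read by MTT assay, with a stated time of 72 h; a lower number here means a stronger inhibitor, a higher number a weaker inhibitor:
- compound 1 `Cc1ccccc1NC(=O)C(Cl)Cl` — compound 1 gives "not determined" (no result reported)
- compound 2 `O=C(Nc1cccc(Cl)c1)C(Cl)Cl` — compound 2 gives 14800 nM
- compound 3 `Cc1ccc(NC(=O)C(Cl)Cl)cc1` — compound 3 gives 48900 nM

For the measured compounds named here, compound 3 holds the higher of the two numbers in this assay, and its gap to compound 2, the only other compound with a number, lies beyond the usual scatter. Compound 1 carries no result, so it adds nothing to the comparison.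

Compound 4 `O=C(Nc1ccc(Cl)cc1)C(Cl)Cl` is the next compound to be measured in this assay. It differs from compound 3 in one place: chloro in place of methyl on an aromatic carbon. Going by the values given here, no step between measured compounds matches this exchange, so the expectation rests on the two numbers alone. Among the compounds with values here, compound 2, the only chloro-bearing compound with a number, sits below compound 3, which leans the expectation toward a somewhat lower number, though of modest size and possibly within the scatter. The step from compound 3 to compound 4 is therefore estimated as a 2.2-fold lower number from compound 3 to compound 4 (0.35 log units; beyond the scatter). For compound 4 in this assay the estimate is 22000 nM, with a range from 7000 nM to 65000 nM.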

Compound 4, half-maximal inhibitory concentration: 20400 nM
Beside the measured number, compound 4's estimate is 1.1-fold (0.03 log units) above it; low and high end bracket the measured number.
By their numbers in this assay, from the lowest: compounds 2 and 4 (each within the scatter of the next); then compound 3.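

In this assay, for the compounds shown here, the exchange of methyl for chloro on an aromatic carbon, para to a group of 6 heavy atoms, gives a 2.4-fold lower number from compound 3 to compound 4 (0.38 log units; beyond the scatter) as the first step that can be read at one and the same position, modest in size. Going by these compounds alone, until now the only chloro-bearing compound with a number was compound 2, which differs from compound 3 in more than one place. Compound 2 and compound 4 lie within the scatter of each other, so the numbers set no order between these two chloro compounds.

From the compounds shown here alone, whether a fluoro, a methoxy, an amine or a carboxylic acid at this position would shift the number further remains open. No measurement shown here bears on why chloro and methyl differ at this position.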